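A few compounds are considered here, and "the series" means these few. Any claim that something is new, unique, unknown or untested is made for them only; others in the source may bear on it.

Three compounds have so far been put through an ADME assay on HCT-116 cells (Homo sapiens) for cytotoxicity, read by CellTiter-Glo, with a stated time of 72 h (a higher number here means a weaker inhibitor, a lower number a stronger inhibitor), and none of them returned an exact number. Compound 1 `Cc1cc(C)c(S(=O)(=O)N2CCN(C3CN4CCC3CC4)CC2)c(C)c1` gives > 5000 nM, which is a limit of the assay. Compound 2 `CC1CCN(C2CCN(S(=O)(=O)c3ccc(-c4ccccc4)cc3)CC2)CC1` gives > 5000 nM, which is also a limit. Compound 3 `CC1CCN(C2CCN(S(=O)(=O)c3cccc4cnccc34)CC2)CC1` gives > 10000 nM, a limit as well. Compound 2 therefore has no exact place on the scale: it stands at the limit of > 5000 nM in this assay, at which 2 of the 3 values shown sit.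

The next compound to be tested is compound 4 `COc1ccc(-c2ccc(S(=O)(=O)N3CCC(N4CCC(C)CC4)CC3)cc2)cc1`. It is compound 2 with a single change, phenyl to 4-methoxyphenyl, which means methoxy in place of hydrogen on an aromatic carbon, para to a large group (methoxy in place of hydrogen on an aromatic carbon).

For the measured compounds named here, no two tested compounds differ in just one place, so there is no measured step to use as a guide. With only limits to go on, the expectation in this assay is that this change makes no difference beyond the usual scatter of repeat measurements, and the assay may well report only a limit again. What is expected is a step that the limit leaves unreadable from compound 2 to compound 4, a small move towards a higher number that stays within that scatter. For compound 4 the estimated value is 6000 nM, with an expected range from 2500 nM to 12000 nM.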

Compound 4, half-maximal inhibitory concentration: > 5000 nM
Compound 4: only a limit was reported; the forecaster's own chance of this, stated with the estimate: 80%; the middle value lies beyond the limit too.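

In this assay compound 4 gives > 5000 nM, which is a limit of the assay. Compound 2 gives > 5000 nM, also a limit, and the step between these two compounds cannot be read. From the compounds shown here alone, whether methoxy in place of hydrogen changes the result at all stays open, as does the exact place of all four compounds on the scale.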